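Replacing a methoxyethyl chain with a branched all-carbon chain

This account rests on a few compounds, and the source may have more. Where it says the series, first, only, none or still open, it means among the compounds named here.

Three measured compounds share one core and differ only in the chain attached to its aromatic nitrogen. In a functional assay on ileum for inhibition of histamine H1 receptor (Cavia porcellus) (a higher number here means a weaker inhibitor, a lower number a stronger inhibitor), compound 1 `C#CCOCCn1c(N2CCN(C)CC2)nc2ccccc21` gives 12 nM. Compound 2 `CCCCCCn1c(N2CCN(C)CC2)nc2ccccc21` gives 26 nM in this assay, and compound 3 `COCCCn1c(N2CCN(C)CC2)nc2ccccc21` gives 860 nM. Compound 3 therefore stands with the highest number of the three, which here means the weakest inhibitor. The measured steps that lead to it are both large: a 33-fold higher number from compound 2 to compound 3 (1.52 log units; beyond the scatter) and a 72-fold higher number from compound 1 to compound 3 (1.86 log units; beyond the scatter). In each case the chain that ends in an oxygen-containing group gives the higher number.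

Compound 4 `CCCC(C)Cn1c(N2CCN(C)CC2)nc2ccccc21` is not yet measured. It differs from compound 3 in one place: 1-methylbutyl in place of 2-methoxyethyl on a saturated chain carbon bound to an aromatic nitrogen. The chain that leaves carries the single hydrogen-bond acceptor; the chain that enters is made of carbon only, as is the chain of compound 2. Among the compounds with values here, the step most closely related is the one from compound 2 to compound 3, read in reverse, and the step from compound 1 to compound 3 points the same way. A large fall in the number is therefore expected. For compound 4 the expected value in this assay is 40 nM, with a range from 10 nM to 160 nM, which corresponds to an expected step of a 22-fold lower number from compound 3 to compound 4 (1.33 log units; beyond the scatter).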

Compound 4, half-maximal inhibitory concentration: 500 nM
Estimate against measurement, compound 4: 13-fold (1.10 log units) below; the measured number lies above the stated range.
By their numbers in this assay, from the lowest: compound 1; then compound 2; then compounds 4 and 3 (each within the scatter of the next).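

Taking the oxygen out of the chain is not enough on its own: in this assay the all-carbon 1-methylbutyl chain cannot be told apart from the 2-methoxyethyl chain, with a 1.7-fold lower number from compound 3 to compound 4 (0.24 log units; within the scatter) as the whole of the difference. Having no oxygen therefore does not divide the stronger inhibitors from the weaker ones: two chains of carbon only can lie far apart, as a 19-fold higher number from compound 2 to compound 4 (1.28 log units; beyond the scatter) shows for pentyl and 1-methylbutyl, and a chain that holds an oxygen can still give a low number, as a 42-fold higher number from compound 1 to compound 4 (1.62 log units; beyond the scatter) shows for the chain of compound 1. No measurement shown here explains why the pentyl and 1-methylbutyl chains give such different numbers.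

From the compounds shown here alone, what stays open is whether the methyl branch itself accounts for that gap, a question that a chain with an ethyl branch or a straight butyl chain would help to answer. The compounds shown also leave open how a chain ending in an amine or a carboxylic acid, or one carrying a cyclohexyl ring, would read in this assay on this core.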